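Series notes: aniline swap on the dimethoxyphenyl urea

The compounds below may be only part of what the source reports. "The series", "measured", "known", "first", "only" and "open" are said of these compounds alone.

Compound 3 `CCc1cccc(Nc2cc(NC(=O)Nc3cc(OC)cc(OC)c3)ncn2)c1` gives 27.7% in a functional assay on NCI-H1581 cells (Homo sapiens) for inhibition, read by MTT assay, with a stated time of 48 h, tested at 10 uM (on this read-out higher numbers stand for more inhibition at the one concentration tested (going by the name of the read-out) and lower numbers for less inhibition), the lowest of the three numbers shown. Compound 1 `CCc1ccc(Nc2cc(NC(=O)Nc3c(Cl)cccc3Cl)ncn2)cc1` gives 38.1% in this assay, a number beyond the scatter above compound 3; compound 2 `COc1ccc(OC)c(Nc2cc(NC(=O)Nc3c(Cl)cccc3Cl)ncn2)c1` gives 93.1% in this assay, the furthest above compound 3. For the measured compounds named here, no pair of measured compounds differs in one place, so no measured step guides the next change.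

Compound 4 `COc1cc(NC(=O)Nc2cc(Nc3ccc(F)c(Cl)c3)ncn2)cc(OC)c1` differs from compound 3 by 3-chloro-4-fluorophenyl in place of 3-ethylphenyl on a nitrogen on an aromatic ring. Compound 4 is expected to sit a little higher than compound 3 in this assay, with the step of a number 12.3 percentage points higher from compound 3 to compound 4 (beyond the scatter) expected to be small, roughly at the edge of the scatter. The estimate for compound 4 in this assay is 40%, within a range of 15% to 70%.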

Compound 4, a percentage reported as inhibition, at one concentration (the size of the read-out at that concentration, not a potency): 53%
Beside the measured number, compound 4's estimate is 13 percentage points below it; the range from low to high includes it.
By their numbers in this assay, from the lowest: compound 3; then compound 1; then compound 4; then compound 2.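

For the compounds shown here, the step of a number 25.3 percentage points higher from compound 3 to compound 4 (beyond the scatter) in this assay is the first measured one-place change: with the dimethoxyphenyl urea held constant, the group on this nitrogen alone moves the read-out beyond the scatter. Compound 1 and compound 2 could not show this, since each differs from compound 3 in more than one place. Nothing measured here bears on the reason for the step.

On these data alone, it remains open whether 3-chloro-4-fluorophenyl would have the same effect on the dichlorophenyl urea of compound 1 and compound 2. Also open, as far as these compounds go, is how a ring carrying an amine or a carboxylic acid would read at this position.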